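Biaryl ortho substituent: cyano replacing isopropyl

The source may hold more compounds than are shown below. What is called first, only, known or untested is meant among the compounds shown, and "the series" means these compounds.

For the measured compounds named here, compound 2 `CC(C)c1ccccc1-c1cccc(COc2ccc(S(=O)(=O)CC(=O)O)cc2)c1` is the higher of the two numbers so far in a functional assay on CHO cells for agonist activity at Free fatty acid receptor 1 (Homo sapiens), read by FLIPR and calcium flux; on this read-out lower numbers stand for an effect already at smaller amounts and higher numbers for an effect only at larger amounts of compound; in this assay compound 2 gives 74.1 nM. Its nearest neighbour is compound 1 `Cc1cccc(C)c1-c1cccc(COc2ccc(S(=O)(=O)CC(=O)O)cc2)c1`, which in this assay gives 66.1 nM, and the step of a 1.1-fold higher number from compound 1 to compound 2 (0.05 log units; within the scatter) lies within the scatter. The change to compound 3 `N#Cc1ccccc1-c1cccc(COc2ccc(S(=O)(=O)CC(=O)O)cc2)c1` is cyano in place of isopropyl on an aromatic carbon, on an aromatic carbon of a six-membered aromatic ring of carbon only, ortho to a large group. Going by the values given here, the single measured step, a 1.1-fold higher number from compound 1 to compound 2 (0.05 log units; within the scatter), swaps one alkyl pattern for another and says little about replacing an alkyl group with a cyano group; there is no measured step with a polar entering group. Among the compounds with values here, the only evidence is that the two alkyl-bearing compounds 1 and 2 sit within the scatter of each other. A modest rise in number is expected for compound 3, but with a wide range given the lack of a comparable step; compound 3 is expected to show a 2.0-fold higher number from compound 2 to compound 3 (0.31 log units; beyond the scatter) relative to compound 2. The estimate for compound 3 in this assay is 150 nM, between 50 nM and 450 nM.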

Compound 3, half-maximal effective concentration: 457 nM
Compound 3: the middle estimate sits 3.0-fold (0.48 log units) below what was measured; measured number outside the range, above it.
By their numbers in this assay, from the lowest: compounds 1 and 2 (each within the scatter of the next); then compound 3.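

In this assay, the place on an aromatic carbon of a six-membered aromatic ring of carbon only, ortho to a large group, proves sensitive to the kind of group it carries: cyano in place of isopropyl gives a 6.2-fold higher number from compound 2 to compound 3 (0.79 log units; beyond the scatter) and lies beyond the scatter, whereas the exchange between the two alkyl patterns, a 1.1-fold higher number from compound 1 to compound 2 (0.05 log units; within the scatter), stayed within it. The comparison with the other alkyl pattern, 2-cyanophenyl in place of 2,6-dimethylphenyl, gives a 6.9-fold higher number from compound 1 to compound 3 (0.84 log units; beyond the scatter) and is also beyond the scatter, so the two alkyl-bearing compounds stand together, apart from the cyano compound, in this small set. No measurement available here accounts for this separation between the alkyl groups and cyano.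

Still open, from the compounds shown here alone, is whether the higher number belongs to cyano alone or extends to other non-alkyl groups at this place, such as a methoxy group, a chlorine atom or an amide. Also open, going by these compounds, is whether a ring carrying both cyano and methyl groups would stay near compound 3 or return towards compounds 1 and 2.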